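Compound 4: a 1-hydroxypropyl isomer of compound 3

The source may report more compounds than this note shows. Statements on the series, on what has been measured and on what is new or still open speak of the compounds shown alone.

Compound 1 (`CC[C@@H](Nc1nc(NCc2ccccn2)c2ncn(C(C)C)c2n1)C(C)(C)O`) gives > 50000 nM in a functional assay on A2780 cells (Homo sapiens) for inhibition, read by sulforhodamine B assay, with a stated time of 96 h (a higher number here means a weaker inhibitor of growth, a lower number a stronger inhibitor of growth), and that value is a limit, not a number. Compound 2 (`CC[C@@H](Nc1nc(NCc2ccccn2)c2ncn(C(C)C)c2n1)C(C)O`) gives 27000 nM in this assay as a measured number. Among the measured compounds shown here, compound 3 (`CC[C@H](Nc1nc(NCc2ccccn2)c2ncn(C(C)C)c2n1)C(C)(C)O`) gives 44000 nM in this assay and so stands within the scatter of compound 2, the only other number available.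

In compound 4 (`CCC(O)[C@H](CC)Nc1nc(NCc2ccccn2)c2ncn(C(C)C)c2n1`), 1-hydroxypropyl stands in place of 1-hydroxy-1-methylethyl on a saturated chain carbon bound to a nitrogen on an aromatic ring and a saturated chain carbon (1-hydroxypropyl in place of 1-hydroxy-1-methylethyl on a saturated chain carbon bound to a nitrogen on an aromatic ring and a saturated chain carbon). The two have the same atoms, joined differently.

All three measured steps alter this same side chain, and none is large. The steps of an at least 1.8-fold lower number from compound 1 to compound 2 (0.26 log units; that floor lies within the scatter) and an at least 1.1-fold lower number from compound 1 to compound 3 (0.05 log units; that floor lies within the scatter) are only floors because of the limit of > 50000 nM in this assay, at which 1 of the 3 values shown sits, and both floors lie within the scatter. The step of a 1.6-fold higher number from compound 2 to compound 3 (0.21 log units; within the scatter) also lies within it. On that basis no step beyond the scatter is expected in this assay for the new isomer. The expected step is a 1.5-fold lower number from compound 3 to compound 4 (0.17 log units; within the scatter) and it remains small. For compound 4 the estimate is 30000 nM with an expected range from 13000 nM to 60000 nM and a reading at the limit remains possible.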

Compound 4, concentration for 50% growth inhibition: 23000 nM
For compound 4 the middle estimate is 1.3-fold (0.12 log units) above the measured one; low and high end bracket the measured number.
By their numbers in this assay, from the lowest: compounds 4, 2 and 3 (each within the scatter of the next). At a limit, above all of these: compound 1.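

Exchanging 1-hydroxy-1-methylethyl for 1-hydroxypropyl on the saturated chain carbon bound to a nitrogen on an aromatic ring does not move the number in this assay beyond the scatter, with a 1.9-fold lower number from compound 3 to compound 4 (0.28 log units; within the scatter), and the comparison with the shorter side chain of compound 2 also stays within it, with a 1.2-fold lower number from compound 2 to compound 4 (0.07 log units; within the scatter). This isomer pair therefore shows that the connectivity change alone gives no readable shift in this assay, while an at least 2.1-fold lower number from compound 1 to compound 4 (0.33 log units; beyond the scatter) is the first step in the series beyond the scatter, though its size is only a floor set by a limit: the limit of > 50000 nM in this assay, at which 1 of the 4 values shown sits.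
That step cannot be assigned to the change of side chain alone, since compound 3, which shares the configuration change relative to compound 1, is the direct partner of compound 4: the fact that compounds 1 and 3 differ only in the configuration as drawn

Whether any side chain at this position can bring the number in this assay clearly beyond the scatter of these compounds remains open. So does the effect of replacing the hydroxyl with an amine or a carboxylic acid, or of extending the side chain to a longer chain such as 1-hydroxybutyl.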